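Swapping a Chlorophenyl Arm for a Dimethylaminophenyl Arm

The source may report more compounds than this note shows. Statements on the series, on what has been measured and on what is new or still open speak of the compounds shown alone.

Measured so far:
Compound 1 `CCOC(=O)c1cnn(-c2nc(-c3ccccc3Cl)c(C#N)c(=O)n2C)c1N` gives 93 ug/mL in a functional assay, with a stated time of 150 min; a higher number here means a weaker inhibitor, a lower number a stronger inhibitor.
Compound 2 `COc1cccc(-c2nc(SC)n(C)c(=O)c2C#N)c1OC` gives 67 ug/mL in this assay.
Compound 3 `Cn1c(NN)nc(-c2ccccc2F)c(C#N)c1=O` gives 60 ug/mL in this assay.

Compound 1 has the highest number of the three, but its gap to compound 2 and its gap to compound 3 both lie within the usual scatter of repeated measurements, so the three read as much alike and none can be ranked as stronger or weaker than another. Within the data shown here, compound 2 and compound 3 also differ from compound 1 in more than one place, so no single step between measured compounds is available to lean on.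

Compound 4 `CCOC(=O)c1cnn(-c2nc(-c3ccc(N(C)C)cc3)c(C#N)c(=O)n2C)c1N` differs from compound 1 in one place: 4-(dimethylamino)phenyl in place of 2-chlorophenyl on an aromatic carbon. Among the measured compounds shown here, nothing among the measured compounds shows what such a change does here, so the expected step in this assay is small, none beyond the scatter in either direction, with wide uncertainty around it. Compound 4 is estimated at 80 ug/mL, between 30 ug/mL and 200 ug/mL. This estimate means a step of a 1.2-fold lower number from compound 1 to compound 4 (0.07 log units; within the scatter) that is expected to stay modest.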

Compound 4, half-maximal inhibitory concentration: 115 ug/mL
Compound 4: middle estimate off by 1.4-fold (0.16 log units), on the low side; low and high end bracket the measured number.
By their numbers in this assay, from the lowest: compounds 3, 2, 1 and 4 (each within the scatter of the next).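

In this assay, placing 4-(dimethylamino)phenyl in place of 2-chlorophenyl on the aromatic carbon ortho to the cyano group gives a 1.2-fold higher number from compound 1 to compound 4 (0.09 log units; within the scatter). Among these compounds, this is the first comparison here in which only one place differs, and it shows that this position accepts a quite different aromatic arm with no readable change in the number. The swap alters both the substituent and where it sits on the phenyl ring, and no measurement offered here explains why the two compounds read alike.

The compounds shown leave open whether the substituent's identity or its location on the arm matters on its own, which a 4-chlorophenyl or 2-(dimethylamino)phenyl arm could separate. They also leave open how a plain phenyl arm, or a saturated cyclohexyl group, would read at this position.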